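This account rests on a few compounds, and the source may have more. Where it says the series, first, only, none or still open, it means among the compounds named here.

Measured so far in a functional assay on Jurkat cells (Homo sapiens) for inhibition; on this read-out higher numbers stand for weaker inhibition and lower numbers for stronger inhibition:
compound 1 `CC(C)[C@H](NC(=O)COc1cccc2ccccc12)C(=O)N[C@@H](CC(=O)O)C(=O)CSc1nc(-c2ccccc2)no1` gives 102000 nM.
compound 2 `CC(C)[C@H](NC(=O)COc1cccc2ccccc12)C(=O)N[C@@H](CC(=O)O)C(=O)COn1nnc2ccccc21` gives > 200000 nM, which is a limit of the assay and not a number.

Compound 2 therefore stands at the limit, (the limit of > 200000 nM in this assay, at which 1 of the 2 values shown sits), with no number of its own in this assay. Going by the values given here, the only measured step, an at least 1.9-fold higher number from compound 1 to compound 2 (0.29 log units; that floor lies within the scatter), concerns the same position that changes again here and reaches only that floor.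

Compound 3 `CC(C)[C@H](NC(=O)COc1cccc2ccccc12)C(=O)N[C@@H](CC(=O)O)C(=O)COc1ccncn1` differs from compound 2 by a group of 6 heavy atoms (4 carbon, 2 nitrogen; one six-membered aromatic ring with 2 hetero atoms) in place of a group of 9 heavy atoms (6 carbon, 3 nitrogen; one five-membered aromatic ring with 3 hetero atoms, one six-membered aromatic ring of carbon only), on an oxygen on a saturated carbon. Among the compounds with values here, no measured step covers a pyrimidin-4-yl group at this position, so the expectation rests on compound 2 sitting at the limit and on the small size of the step from compound 1 to compound 2. Compound 3 is expected to remain weak, with an estimated step of an at least 1.1-fold lower number from compound 2 to compound 3 (0.04 log units; that floor lies within the scatter) in this assay, most likely again reported only as a limit.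

Compound 3 is estimated at 180000 nM, in the range 50000 nM to 600000 nM.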

Compound 3, half-maximal inhibitory concentration: > 200000 nM
Compound 3 was reported as a limit; the forecaster's own chance of this, stated with the estimate: 65%; at least 1.1-fold (0.04 log units) between middle value and limit.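

In this assay, the pyrimidin-4-yl group gives a second compound at this place without a number of its own: compound 3 gives > 200000 nM, which is a limit of the assay. On these data alone, replacing the (3-phenyl-1,2,4-oxadiazol-5-yl)sulfanyl group, on the saturated chain carbon bound to a carbonyl carbon, gives an at least 1.9-fold higher number from compound 1 to compound 3 (0.29 log units; that floor lies within the scatter), so the true size of this change stays unknown. The step between the two limits cannot be read, and a bicyclic group and a single ring on the oxygen now end at the same limit: the limit of > 200000 nM in this assay, at which 2 of the 3 values shown sit.

As far as these compounds go, whether any group at this place moves the number beyond the scatter from compound 1 remains open. A (pyrimidin-4-yl)sulfanyl group or an amine on the same carbon would help separate the effect of the linking atom from that of the ring.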